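The source may report more compounds than this note shows. Statements on the series, on what has been measured and on what is new or still open speak of the compounds shown alone.

Working notes on the series. In a functional assay on KYSE-510 cells (Homo sapiens) for antiproliferative activity, read by crystal violet staining, with a stated time of 96 h (a lower number here means a stronger inhibitor of growth, a higher number a weaker inhibitor of growth), compound 2 `Cc1cc(C)c(S(=O)(=O)NC2=NCCN2C(=S)SN2CCn3c2nsc3=S)c(C)c1` gives only a limit, >= 20000 nM. Compound 1 `O=S(=O)(NC1=NCCN1C(=S)SN1CCn2c1nsc2=S)c1ccccc1` likewise stands at a limit, >= 20000 nM. Compound 3 `O=S(=O)(NC1=NCCN1C(=S)SN1CCn2c1nsc2=S)c1cccc(Cl)c1` also reaches only a limit, >= 20000 nM. Compound 2 therefore sits at the same boundary as both neighbours, as the limit of >= 20000 nM in this assay, at which 3 of the 3 values shown sit, records. The next compound, compound 4 `O=S(=O)(NC1=NCCN1C(=S)SN1CCn2c1nsc2=S)c1ccc2ccccc2c1`, carries the change (naphthalen-2-yl in place of 2,4,6-trimethylphenyl on a sulfonyl sulfur). The measured steps that touch compound 2 are a step that the two limits leave unreadable from compound 1 to compound 2 and a step that the two limits leave unreadable from compound 2 to compound 3; neither has a readable size, as both ends sit at limits. No step beyond the scatter in either direction can be expected in this assay, and for compound 4 the expected step is a number no higher from compound 2 to compound 4 (the limit leaves the size open). The estimate for compound 4 is 20000 nM, with a range from 8000 nM to 50000 nM.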

Compound 4, concentration for 50% growth inhibition: >= 20000 nM
Compound 4 was reported as a limit; the forecaster's own chance of this, stated with the estimate: 80%; the middle value sits exactly at the limit.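

No step can be read between compound 4 and compound 1, compound 2 or compound 3, as all four stand at one boundary: the limit of >= 20000 nM in this assay, at which 4 of the 4 values shown sit.

The compounds shown leave open whether the group on the sulfonyl sulfur affects the result in this assay at all.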